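Chalcones on a shared core against colon cancer cells

The source may report more compounds than this note shows. Statements on the series, on what has been measured and on what is new or still open speak of the compounds shown alone.

Measured so far:
- compound 1, `COc1ccc(C(=O)/C=C/c2cccc(F)c2)c2c1C=CC(C)(C)O2`, in a functional assay on HCT-116 cells (Homo sapiens) for antiproliferative activity, read by MTT assay, with a stated time of 24 h; a lower number here means a stronger inhibitor, a higher number a weaker inhibitor: > 10000 nM
- compound 2, `COc1ccc(C(=O)/C=C/c2ccc(Cl)c(Cl)c2)c2c1C=CC(C)(C)O2`, in this assay: 9440 nM

Compound 1 gives only a limit of the assay, (the limit of > 10000 nM in this assay, at which 1 of the 2 values shown sits), and not a number. Going by the values given here, compound 2 is therefore the only compound with a number, and that number sits close to the limit. Among the compounds with values here, the one measured step, an at least 1.0-fold lower number from compound 1 to compound 2 (0.02 log units; that floor lies within the scatter), lies within the scatter.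

Compound 3, `COc1ccccc1/C=C/C(=O)c1ccc(OC)c2c1OC(C)(C)C=C2`, has not yet been measured. It differs from compound 2 by 2-methoxyphenyl in place of 3,4-dichlorophenyl on a double-bonded chain carbon bound to a double-bonded chain carbon. Within the data shown here, the only comparable step, an at least 1.0-fold lower number from compound 1 to compound 2 (0.02 log units; that floor lies within the scatter), is within the scatter, so no step beyond the scatter is expected here in either direction. Compound 3 is therefore expected at 10000 nM, with a range from 4000 nM to 25000 nM, a step of a 1.1-fold higher number from compound 2 to compound 3 (0.03 log units; within the scatter) that may well again fall as a limit.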

Compound 3, half-maximal inhibitory concentration: > 10000 nM
Compound 3: only a limit was reported; the forecaster's own chance of this, stated with the estimate: 50%; the middle value sits exactly at the limit.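

Replacing 3,4-dichlorophenyl with 2-methoxyphenyl gives an at least 1.0-fold higher number from compound 2 to compound 3 (0.02 log units; that floor lies within the scatter). With this change, a group holding a hydrogen-bond acceptor joins the halogen-bearing groups at this place, and compound 3 yields only a limit in this assay, not a number. The series now rests largely on the edge of the assay: the limit of > 10000 nM in this assay, at which 2 of the 3 values shown sit. The step between compound 1 and compound 3 cannot be read.

Open, from the compounds shown here alone, is whether an amine or a carboxylic acid on this phenyl ring would give a number clearly beyond the scatter of compound 2.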